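The source may report more compounds than this note shows. Statements on the series, on what has been measured and on what is new or still open speak of the compounds shown alone.

Measured so far in a functional assay on Daoy cells (Homo sapiens) for antiproliferative activity, read by trypan blue exclusion and crystal violet staining, with a stated time of 72 h; a lower number here means a stronger inhibitor, a higher number a weaker inhibitor:
compound 1 `O=C(NC(c1ccc(Cl)cc1Cl)c1ccc2cccnc2c1O)C1CCCC1` gives 150 nM
compound 2 `CCCCC(=O)NC(c1ccc(Cl)c(Cl)c1)c1ccc2cccnc2c1O` gives 100 nM
compound 3 `CCCCC(=O)NC(c1cc(Cl)cc(Cl)c1)c1ccc2cccnc2c1O` gives 140 nM

Among these three, compound 1 has the highest number, yet its gaps to compound 3 and to compound 2 both lie within the scatter, so the three cannot be ranked against each other. Among the compounds with values here, the one measured step, a 1.4-fold higher number from compound 2 to compound 3 (0.15 log units; within the scatter), alters the chlorine pattern on the phenyl ring and does not touch the amide side of the shared core, so it does not bear on the change considered here. Compound 4 `O=C(NC(c1ccc(Cl)cc1Cl)c1ccc2cccnc2c1O)C1CCCCC1` differs from compound 1 in that (cyclohexyl in place of cyclopentyl on a carbonyl carbon). Within the data shown here, with no step of this kind measured, the change is expected to stay within the scatter, so a 1.2-fold lower number from compound 1 to compound 4 (0.06 log units; within the scatter) is the estimate. Compound 4 is therefore expected to give about 130 nM, in the range 60 nM to 300 nM.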

Compound 4, half-maximal inhibitory concentration: 240 nM
Compound 4: middle estimate off by 1.8-fold (0.27 log units), on the low side; the range from low to high includes it.
By their numbers in this assay, from the lowest: compounds 2, 3, 1 and 4 (each within the scatter of the next, the first and the last beyond it).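

In this assay, cyclohexyl in place of cyclopentyl on a carbonyl carbon gives a 1.6-fold higher number from compound 1 to compound 4 (0.20 log units; within the scatter). Within the data shown here, this is the first measured step at this place, and it shows that one more ring carbon leaves a difference that cannot be told apart from repeat measurements. No measured evidence here bears on this result.

The compounds shown leave open whether a much smaller ring such as cyclopropyl, or a ring carrying an amine such as piperidine, would stay in the same range at this place.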